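A few compounds are considered here, and "the series" means these few. Any claim that something is new, unique, unknown or untested is made for them only; others in the source may bear on it.

Compound 1 `CCCN(C)c1ncnc2[nH]cc(-c3cccc(Cl)c3)c12` gives 218 nM in an assay for inhibition of serine/threonine-protein kinase 3 (Homo sapiens), read by luminescence and ADP-Glo, in the presence of a further agent that is not named here; on this read-out lower numbers stand for stronger inhibition and higher numbers for weaker inhibition.
Compound 2 `CC(=O)NC1CCN(c2ncnc3[nH]cc(-c4cccc(Cl)c4)c23)CC1` gives 36 nM in this assay.
Compound 3 `CNC1CCN(c2ncnc3[nH]cc(-c4cccc(Cl)c4)c23)CC1` gives 293 nM in this assay.

Among these three numbers compound 3 has the highest. Its gap to compound 1 is within the scatter, so these two cannot be ordered; compound 2 stands clearly lower, as the step of an 8.1-fold higher number from compound 2 to compound 3 (0.91 log units; beyond the scatter) shows, which exchanged only the acetyl on the amine nitrogen for a methyl.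

Compound 4 `CN(C)c1ncnc2[nH]cc(-c3cccc(Cl)c3)c12` differs from compound 3 in one place: dimethylamino in place of 4-(methylamino)piperidin-1-yl on an aromatic carbon. Going by the values given here, the one measured step that bears on this is a 1.3-fold higher number from compound 1 to compound 3 (0.13 log units; within the scatter), where an open-chain amine on the same aromatic carbon was replaced by the piperidine and the number hardly moved. Among the compounds with values here, no measured step compares two open-chain amines of different size with each other, so the dimethylamino of compound 4 is judged by analogy with compound 1 only. For compound 4 the expected step of a 1.2-fold higher number from compound 3 to compound 4 (0.08 log units; within the scatter) is therefore one within the scatter, with no clear direction. Compound 4 is estimated at 350 nM, within 120 nM to 1100 nM.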

Compound 4, half-maximal inhibitory concentration: 349 nM
Beside the measured number, compound 4's estimate is 1.0-fold (0.00 log units) above it; the range from low to high includes it.
By their numbers in this assay, from the lowest: compound 2; then compounds 1, 3 and 4 (each within the scatter of the next).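

Replacing the whole 4-(methylamino)piperidin-1-yl with the much smaller dimethylamino gives a 1.2-fold higher number from compound 3 to compound 4 (0.08 log units; within the scatter), so on this aromatic carbon the piperidine ring and its amine can go without any change that can be read. The comparison between two open-chain amines, absent until now, gives a 1.6-fold higher number from compound 1 to compound 4 (0.20 log units; within the scatter), so removing ethyl from the chain also leaves no readable change. Among the steps shown, the only one beyond the scatter remains an 8.1-fold higher number from compound 2 to compound 3 (0.91 log units; beyond the scatter), which lies on the piperidine's amine nitrogen and not in the size of the group on the aromatic carbon.

Nothing shown here explains why these amines give such close numbers.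

From the compounds shown here alone, it also remains open whether a morpholine or a piperidine carrying a carboxylic acid at this position would give a number that stands apart from these amines.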